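Aryl variation on the ring nitrogen: estimating compound 3

The source may hold more compounds than are shown below. What is called first, only, known or untested is meant among the compounds shown, and "the series" means these compounds.

Measured so far:
compound 1 `COc1cc2ncnc(Nc3ccc(Cl)c(C(F)(F)F)c3)c2cc1OCCCCC(=O)Nc1ccc(S(N)(=O)=O)cc1` gives 3220 nM in a functional assay on NCI-H1975 cells (Homo sapiens) for antiproliferative activity, read by MTT assay, with a stated time of 72 h; on this read-out higher numbers stand for weaker inhibition and lower numbers for stronger inhibition
compound 2 `COc1cc2ncnc(Nc3ccc(Br)cc3)c2cc1OCCCCC(=O)Nc1ccc(S(N)(=O)=O)cc1` gives 23300 nM in this assay

Going by the values given here, compound 2 stands highest of the two numbers in this assay; its only neighbour is compound 1, and the step of a 7.2-fold higher number from compound 1 to compound 2 (0.86 log units; beyond the scatter) separates them, beyond the scatter. Compound 3 `COc1cc2ncnc(Nc3ccc(F)c(Br)c3)c2cc1OCCCCC(=O)Nc1ccc(S(N)(=O)=O)cc1` awaits measurement. It differs from compound 2 by 3-bromo-4-fluorophenyl in place of 4-bromophenyl on a nitrogen on an aromatic ring. Among the compounds with values here, the single step that bears on this change is a 7.2-fold higher number from compound 1 to compound 2 (0.86 log units; beyond the scatter): there the 4-chloro-3-(trifluoromethyl)phenyl of compound 1 gave the lower number and the 4-bromophenyl of compound 2 the higher. The 3-bromo-4-fluorophenyl of compound 3 again carries two halogens on the ring, as compound 1 does, while the atoms themselves differ. A partial return toward compound 1 is therefore expected, in the direction of a lower number, and the expected step is a 3.3-fold lower number from compound 2 to compound 3 (0.52 log units; beyond the scatter). The estimate for compound 3 in this assay is 7000 nM, with a range of 2500 nM to 20000 nM.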

Compound 3, half-maximal inhibitory concentration: 31600 nM
Estimate against measurement, compound 3: 4.5-fold (0.65 log units) below; the whole stated range lies below it.
By their numbers in this assay, from the lowest: compound 1; then compounds 2 and 3 (each within the scatter of the next).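

In this assay the step to 3-bromo-4-fluorophenyl from 4-bromophenyl on the nitrogen reads as a 1.4-fold higher number from compound 2 to compound 3 (0.13 log units; within the scatter) and so does not separate the two compounds at this position. With a 9.8-fold higher number from compound 1 to compound 3 (0.99 log units; beyond the scatter) as the other new step, the 4-chloro-3-(trifluoromethyl)phenyl of compound 1 stands apart from both other aryl groups, and a second halogen on the ring does not by itself bring the number back toward compound 1. Nothing available here speaks to the reason for this.

Still open, from the compounds shown here alone, is whether the trifluoromethyl alone accounts for the lower number of compound 1, and how a nitrile or an amine on this aryl ring would read. Equally open, going by these compounds, is whether a shorter chain, or a carboxylic acid in place of the sulfonamide, would shift these numbers.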